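The source may hold more compounds than are shown below. What is called first, only, known or untested is meant among the compounds shown, and "the series" means these compounds.

compound 1 `O=C(CSc1nc(Cc2c(Cl)cccc2Cl)cc(=O)[nH]1)c1ccc(F)cc1` in an ADME assay on MT4 cells (Homo sapiens) for cytotoxicity, read by MTT assay (on this read-out higher numbers stand for lower toxicity in this test and lower numbers for higher toxicity in this test), gives > 59000 nM as a limit
compound 2 `Cc1c(Cc2c(Cl)cccc2Cl)nc(SCC(=O)c2ccc(F)cc2)[nH]c1=O` in this assay gives > 57000 nM as a limit
compound 3 `CCc1c(Cc2c(Cl)cccc2Cl)nc(SCC(=O)c2ccccc2)[nH]c1=O` in this assay gives > 52000 nM as a limit

Among the measured compounds shown here, none of the three measured compounds has a numerical value in this assay so far. Compound 3 stands at the limit of > 52000 nM in this assay, at which 1 of the 3 values shown sits, and so offers a limit as the starting point, not a number.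

The next structure is compound 4 `CCc1c(Cc2c(Cl)cccc2Cl)nc(SCC(=O)c2ccc(F)cc2)[nH]c1=O` and the change is fluoro in place of hydrogen on an aromatic carbon on the benzoyl group, which becomes (4-fluorophenyl)carbonyl.

For the measured compounds named here, the one measured step is a step that the two limits leave unreadable from compound 1 to compound 2 and it concerns a different change, methyl in place of hydrogen on an aromatic carbon, so it gives no size to carry over. The 4-fluorophenyl group entering here is already present in compound 1, which gives > 59000 nM as a limit only. The same group is present in compound 2, which gives > 57000 nM as a limit only.

The data therefore offer no measured size for this change, and none beyond the scatter is expected. The expected step is a step that the limit leaves unreadable from compound 3 to compound 4 and it should stay within the scatter. Compound 4 will most likely be reported as a limit again. For compound 4 the estimated value is 54000 nM with an expected range of 30000 nM to 70000 nM in this assay as the assay concerned.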

Compound 4, half-maximal cytotoxic concentration: > 55000 nM
Compound 4 was reported as a limit (the forecaster's own chance of this, stated with the estimate: 85%); at least 1.0-fold (0.00 log units) between middle value and limit.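

In this assay compound 4 gives > 55000 nM, which is a limit. The steps from compound 1, compound 2 and compound 3 to compound 4 cannot be read: each joins two limits. The compounds shown leave open where the half-maximal cytotoxic concentration of any of them lies, and whether the fluoro, methyl or ethyl changes shift it at all.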